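From hydroxy to methoxy on compound 3

The source may report more compounds than this note shows. Statements on the series, on what has been measured and on what is new or still open speak of the compounds shown alone.

In an ADME assay on CNE-2 cells (Homo sapiens) for cytotoxicity, read by MTT assay, with a stated time of 48 h (on this read-out lower numbers stand for stronger inhibition and higher numbers for weaker inhibition), compound 1 `COc1ccc(-c2cn(Cc3ccc(C(C)(C)C)cc3)nn2)cc1` gives 4000 nM. Compound 2 `COc1ccc(-c2cn(Cc3ccc(C(C)(C)C)cc3)nn2)c(N)c1` gives > 20000 nM, which is a limit of the assay and not a number. Within the data shown here, compound 3 `CC(C)(C)c1ccc(Cn2cc(-c3ccc(O)cc3[N+](=O)[O-])nn2)cc1` gives 1600 nM, the lowest of the two true numbers so far.

Compound 4 `COc1ccc(-c2cn(Cc3ccc(C(C)(C)C)cc3)nn2)c([N+](=O)[O-])c1` differs from compound 3 by one change, methyl in place of hydrogen on an oxygen on an aromatic ring, or hydroxy to methoxy. Among the measured compounds shown here, no measured pair shows this change. For the measured compounds named here, the only measured step, an at least 5.0-fold higher number from compound 1 to compound 2 (0.69 log units; beyond the scatter), puts amino in place of hydrogen on an aromatic carbon, so it bears only loosely: it shows that one small substitution can move the number beyond the scatter.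

Compound 1 also carries a methoxy group and gives 4000 nM, so a true number rather than a limit is expected here. The expected step is small and points to a higher number, a 1.9-fold higher number from compound 3 to compound 4 (0.27 log units; within the scatter). For compound 4 the estimated value is 3000 nM, with an expected range from 1000 nM to 10000 nM.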

Compound 4, half-maximal inhibitory concentration: 1600 nM
Compound 4: middle estimate off by 1.9-fold (0.27 log units), on the high side; low and high end bracket the measured number.
By their numbers in this assay, from the lowest: compounds 3 and 4 (each within the scatter of the next); then compound 1. At a limit, above all of these: compound 2.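

In this assay, the methyl on the oxygen on the aromatic ring makes no measurable difference when the nitro group is present (no change at the digits printed from compound 3 to compound 4 (within the scatter)). With the methoxy held fixed, the nitro group is what counts here: nitro in place of hydrogen gives a number beyond the scatter (a 2.5-fold lower number from compound 1 to compound 4 (0.40 log units; beyond the scatter)), and nitro in place of amino gives a large step (an at least 12-fold lower number from compound 2 to compound 4 (1.09 log units; beyond the scatter)). Compound 2 gives a limit of the assay and not a number, so that last step has no exact size: the limit of > 20000 nM in this assay, at which 1 of the 4 values shown sits.

Going by these compounds, what a hydroxy does on the core of compound 1, without the nitro group, stays open. So does the effect of an ethyl or a longer chain on this oxygen, or of a carboxylic acid or a chlorine in place of the nitro group.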